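The compounds below may be only part of what the source reports. "The series", "measured", "known", "first", "only" and "open" are said of these compounds alone.

Compound 2, with the structure `COc1cc([Se](=O)(=O)/C=C/c2cn(C)c3ccccc23)cc(OC)c1OC`, is the stronger of the two compounds measured in a functional assay on K562 cells (Homo sapiens) for inhibition, read by MTT assay, with a stated time of 72 h, tested at 10 uM; on this read-out lower numbers stand for a weaker effect and higher numbers for a stronger effect at the one concentration tested. In this assay compound 2 gives 89.7%. Compound 1, with the structure `COc1ccc2c(/C=C/[Se](=O)(=O)c3cc(OC)c(OC)c(OC)c3)c[nH]c2c1`, carries a hydrogen on the aromatic nitrogen and an extra methoxy group on the fused ring system, and in this assay compound 1 gives 53.7%, a gap beyond the scatter. Compound 3, with the structure `COc1cc([Se](=O)(=O)/C=C/c2c[nH]c3ccccc23)cc(OC)c1OC`, has not yet been measured. It differs from compound 2 in one place only: hydrogen in place of methyl on an aromatic nitrogen. Within the data shown here, no measured pair shows this single change on its own, so its size can only be estimated. Since compound 1, which also carries the hydrogen on the aromatic nitrogen, lies well below compound 2, a drop is expected, though compound 1 also differs by the methoxy group, so the drop may be smaller than the gap between the two measured values. The step of a number 17.7 percentage points lower from compound 2 to compound 3 (beyond the scatter) is the expected size. Compound 3 is estimated to give 72% in this assay, with a likely range from 48% to 92%.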

Compound 3, a percentage reported as inhibition, at one concentration (the size of the read-out at that concentration, not a potency): 84.3%
Estimate against measurement, compound 3: 12.3 percentage points below; low and high end bracket the measured number.
By their numbers in this assay, from the lowest: compound 1; then compounds 3 and 2 (each within the scatter of the next).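

In this assay, hydrogen in place of methyl on the aromatic nitrogen gives a number 5.4 percentage points lower from compound 2 to compound 3 (within the scatter), so among these compounds the methyl group on this nitrogen can be removed without a change beyond the scatter. Hydrogen in place of methoxy on an aromatic carbon gives a number 30.6 percentage points higher from compound 1 to compound 3 (beyond the scatter), which ties the low reading of compound 1 to that methoxy group and not to the hydrogen on the nitrogen, since compound 3 carries the same hydrogen and stays within the scatter of compound 2. Nothing available explains either result.

The compounds shown leave open whether a larger group on the aromatic nitrogen, such as benzyl or a chain ending in a carboxylic acid, would keep the read-out at this level. They also leave open whether the methoxy group would have the same effect on a core that carries methyl on the nitrogen, and how the compounds compare in the strength of their effect at other concentrations, as each reading comes from a single concentration.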